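The compounds below may be only part of what the source reports. "The series", "measured", "known", "first", "only" and "open" are said of these compounds alone.

Compound 3 `O=C(COc1cccc2ccccc12)N/N=C/c1ccc([N+](=O)[O-])cc1` gives 87.9 ug/mL in an ADME assay on MT4 cells (Homo sapiens) for cytotoxicity, read by MTT assay, with a stated time of 4 days (a higher number here means that more compound is tolerated, a lower number that less compound is tolerated), the highest of the three numbers in hand. Compound 2 `COc1ccc(/C=N/NC(=O)COc2cccc3ccccc23)cc1OC` gives 14.7 ug/mL, and compound 1 `COc1cc(/C=N/NC(=O)COc2cccc3ccccc23)cc(OC)c1OC` gives 13.4 ug/mL; both gaps from compound 3 lie beyond the scatter. For the measured compounds named here, the only measured step, a 1.1-fold higher number from compound 1 to compound 2 (0.04 log units; within the scatter), lies within the scatter and does not touch the substituent that changes here. Compound 4 `CSc1ccc(/C=N/NC(=O)COc2cccc3ccccc23)cc1` differs from compound 3 by methylsulfanyl in place of nitro on an aromatic carbon. Going by the values given here, no measured step bears on this exchange; the nearest guidance is that the two compounds without nitro, compound 1 at 13.4 ug/mL and compound 2 at 14.7 ug/mL, sit well below compound 3. A downward step of uncertain size is therefore expected. Compound 4 is estimated at 30 ug/mL, range 10 ug/mL to 100 ug/mL, meaning an expected step of a 2.9-fold lower number from compound 3 to compound 4 (0.47 log units; beyond the scatter).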

Compound 4, half-maximal cytotoxic concentration: 68.3 ug/mL
Compound 4: the middle estimate sits 2.3-fold (0.36 log units) below what was measured, and the stated range covers the measured number.
By their numbers in this assay, from the lowest: compounds 1 and 2 (each within the scatter of the next); then compounds 4 and 3 (each within the scatter of the next).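

In this assay, methylsulfanyl in place of nitro on this aromatic carbon, para to a large group, gives a 1.3-fold lower number from compound 3 to compound 4 (0.11 log units; within the scatter), so the two compounds cannot be told apart. For the compounds shown here, this is the first measured exchange at this position, and it shows that nitro is not required there for a number of this size. No measurement available on these compounds accounts for this result.

Open, going by these compounds, is how an amine or a carboxylic acid on this carbon would read. Also open, on these data alone, is the effect of methoxy alone here, since compounds 1 and 2 each differ from compound 3 in more than one place.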